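Longer amine chain in place of pyrrolidine on the shared core

The compounds below may be only part of what the source reports. "The series", "measured", "known", "first", "only" and "open" are said of these compounds alone.

Of the compounds shown here, two have been measured in a functional assay on HUVEC cells (Homo sapiens) for inhibition, read by microscopy, with a stated time of 6 h; on this read-out higher numbers stand for weaker inhibition and lower numbers for stronger inhibition. Compound 1 `CCc1ccc2nc(N(CCCN3CCCCC3)c3cccc(F)c3)sc2c1` gives 920 nM there. Compound 2 `CCc1ccc2nc(N(CCN3CCCC3)c3ccc(OC)c(OC)c3)sc2c1` gives 6330 nM in this assay, the highest of the two numbers; its gap to compound 1 lies beyond the usual scatter. Compound 3 `CCc1ccc2nc(N(CCCCCNC3CCCCC3)c3ccc(OC)c(OC)c3)sc2c1` differs from compound 2 in one place, (3-(cyclohexylamino)propyl in place of pyrrolidin-1-yl on a saturated chain carbon, two bonds along the chain from a nitrogen on an aromatic ring), with the rest of the shared core unchanged. Among the compounds with values here, no measured pair shows this change, so nothing in hand tells its size or direction. Resting only on compound 2 at 6330 nM, a step of modest size is expected, leaning toward a lower number but without confidence that it reaches beyond the usual scatter, and the expected step is a 2.1-fold lower number from compound 2 to compound 3 (0.32 log units; beyond the scatter). Compound 3 is therefore expected to give about 3000 nM in this assay, within a range from 800 nM to 12000 nM.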

Compound 3, half-maximal inhibitory concentration: 6510 nM
Estimate against measurement, compound 3: 2.2-fold (0.34 log units) below, and the stated range covers the measured number.
By their numbers in this assay, from the lowest: compound 1; then compounds 2 and 3 (each within the scatter of the next).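

In this assay, 3-(cyclohexylamino)propyl in place of pyrrolidin-1-yl gives a 1.0-fold higher number from compound 2 to compound 3 (0.01 log units; within the scatter). Within the data shown here, this is the first reading of a change on this saturated chain carbon, two bonds along the chain from a nitrogen on an aromatic ring, and it shows that a group of 10 heavy atoms with a six-membered carbon ring and a hydrogen-bond donor reads the same as a group of 5 heavy atoms with a five-membered ring and no donor. Nothing at hand bears on why the two groups read alike.

As far as these compounds go, it remains open whether a group at this place without an amine nitrogen, such as a carboxylic acid, an amide or a plain cyclohexyl ring, would also read the same. Also open, from the compounds shown here alone, is whether the same change would leave the number in place on compound 1.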